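Swapping Trifluoromethyl for Chloro on the Urea Aryl Ring

The compounds below may be only part of what the source reports. "The series", "measured", "known", "first", "only" and "open" are said of these compounds alone.

In a functional assay on SK-MEL-2 cells (Homo sapiens) for inhibition, read by sulforhodamine B assay, with a stated time of 48 h (on this read-out lower numbers stand for stronger inhibition of growth and higher numbers for weaker inhibition of growth), compound 2 `COc1cc2cc(Oc3ccc(NC(=O)Nc4ccc(Cl)c(C(F)(F)F)c4)cc3)c(C)nc2cc1OC` gives 799 nM, the lowest of the two numbers shown. Its nearest neighbour, compound 1 `COc1cc2cc(Oc3ccc(NC(=O)Nc4cccc(C(F)(F)F)c4)cc3)c(C)nc2cc1OC`, gives 1280 nM in this assay, and the step of a 1.6-fold lower number from compound 1 to compound 2 (0.20 log units; within the scatter) lies within the scatter. Compound 3 `COc1cc2cc(Oc3ccc(NC(=O)Nc4ccc(Cl)c(Cl)c4)cc3)c(C)nc2cc1OC` differs from compound 2 by chloro in place of trifluoromethyl on an aromatic carbon. Within the data shown here, the only measured step, that from compound 1 to compound 2, concerns a chloro entering where hydrogen stood and bears only loosely on the present exchange; being within the scatter, it offers no ground for expecting a large shift. The trifluoromethyl-to-chloro exchange itself has no measured counterpart among these compounds. The step of a 1.3-fold higher number from compound 2 to compound 3 (0.10 log units; within the scatter) is therefore expected to stay within the scatter. The estimate for compound 3 in this assay is 1000 nM, expected to range from 400 nM to 2500 nM.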

Compound 3, concentration for 50% growth inhibition: 3000 nM
Beside the measured number, compound 3's estimate is 3.0-fold (0.48 log units) below it; measured number outside the range, above it.
By their numbers in this assay, from the lowest: compounds 2 and 1 (each within the scatter of the next); then compound 3.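

In this assay this position proves sensitive to the change: chloro in place of trifluoromethyl gives a 3.8-fold higher number from compound 2 to compound 3 (0.57 log units; beyond the scatter) and is the first step among these compounds to lie beyond the scatter. The 3,4-dichlorophenyl group also compares unfavourably with the 3-(trifluoromethyl)phenyl group, with a 2.3-fold higher number from compound 1 to compound 3 (0.37 log units; beyond the scatter) as the result, whereas the chloro entering where hydrogen stood left the number within the scatter, so among these three compounds the clear shifts come only where trifluoromethyl leaves. No measurement at hand offers an explanation for this shift.

On these data alone, whether a nitrile, a methyl or an amine at this position would hold the number near that of compound 2 remains open. So does whether the loss on removing trifluoromethyl would be of similar size without the chloro already on the ring.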